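Chlorothiophene in Place of Methylpyridine: An Expected Recovery

A few compounds are considered here, and "the series" means these few. Any claim that something is new, unique, unknown or untested is made for them only; others in the source may bear on it.

Compound 1 `COc1ccccc1-n1nc(C2CC(C)(C)OC(C)(C)C2)cc1-c1ccc(Cl)cc1` gives 16 nM in an assay on HEK293 cells for inhibition of Voltage-dependent N-type calcium channel subunit alpha-1B (Homo sapiens), read by patch clamp, using a membrane potential dye; a lower number here means a stronger inhibitor, a higher number a weaker inhibitor.
Compound 2 `COc1ccccc1-n1nc(C2CC(C)(C)OC(C)(C)C2)cc1-c1ccc(C)nc1` gives 13000 nM in this assay.

Among the compounds with values here, of the two measured compounds, compound 2 stands at the higher number, so it is the weaker inhibitor, and the single measured step separates it from compound 1: an 810-fold higher number from compound 1 to compound 2 (2.91 log units; beyond the scatter). Compound 3 `COc1ccccc1-n1nc(C2CC(C)(C)OC(C)(C)C2)cc1-c1csc(Cl)c1` has not been measured. It differs from compound 2 in one place: 5-chlorothiophen-3-yl in place of 6-methylpyridin-3-yl on an aromatic carbon. Within the data shown here, the one measured step bears directly on this change, because an 810-fold higher number from compound 1 to compound 2 (2.91 log units; beyond the scatter) shows how much the number rose when the 6-methylpyridin-3-yl group replaced a chlorine-bearing aromatic ring at the same place. The group entering in compound 3 again carries a chlorine, now on a five-membered aromatic ring with a sulfur rather than a six-membered one, so compound 3 resembles compound 1 more than compound 2 there. The expected outcome is therefore a large fall in number, a 220-fold lower number from compound 2 to compound 3 (2.34 log units; beyond the scatter), though compound 1 with its 16 nM may not be matched exactly since the ring size also changes. For compound 3 the estimate in this assay is 60 nM, with a range from 12 nM to 400 nM.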

Compound 3, half-maximal inhibitory concentration: 28 nM
Estimate against measurement, compound 3: 2.1-fold (0.33 log units) above; the range from low to high includes it.
By their numbers in this assay, from the lowest: compounds 1 and 3 (each within the scatter of the next); then compound 2.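

In this assay, putting the 5-chlorothiophen-3-yl group at this place on the five-membered ring undoes nearly all of the loss seen with the methylpyridine, with a 460-fold lower number from compound 2 to compound 3 (2.67 log units; beyond the scatter) as the step. The comparison with the chlorophenyl compound gives a 1.8-fold higher number from compound 1 to compound 3 (0.24 log units; within the scatter) and so lies within the scatter, which means that compound 1 and compound 3 cannot be told apart here although one carries a six-membered aromatic ring and the other a five-membered one with sulfur. Among these three compounds, the two groups with a chlorine give similar numbers whatever their ring size, while compound 2, with 6-methylpyridin-3-yl and no chlorine, stands alone at a far higher number.

Nothing available explains why these groups give such different numbers. The compounds shown also cannot separate the roles of the chlorine, the pyridine nitrogen and the methyl group, a question that a comparison of 6-chloropyridin-3-yl and 4-methylphenyl at this same place could begin to address.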